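Swapping a Benzyl Sulfone for an Aryl Sulfonamide

The source may report more compounds than this note shows. Statements on the series, on what has been measured and on what is new or still open speak of the compounds shown alone.

Measured compounds:
compound 1 `Cn1c(=O)c(S(=O)(=O)Cc2ccc(F)cc2F)cc2cnc(Nc3ccc4[nH]ccc4c3)nc21` — 1000 nM
compound 2 `Cn1c(=O)c(S(=O)(=O)c2ccc(F)cc2F)cc2cnc(Nc3ccc4[nH]ncc4c3)nc21` — 30000 nM
compound 3 `O=c1c(S(=O)(=O)c2ccc(F)cc2F)cc2cnc(Nc3ccc4[nH]ccc4c3)nc2n1CC1CC1` — 1000 nM

In a functional assay on DU-145 cells (Homo sapiens) for inhibition, read by trypan blue exclusion, with a stated time of 72 h (on this read-out higher numbers stand for weaker inhibition and lower numbers for stronger inhibition), compound 1 gives 1000 nM. Compound 3 gives 1000 nM, the same number at the digits shown, so the two sit within the usual scatter of each other and together form the lowest pair of the three. Compound 2 gives 30000 nM, a much higher number that lies well beyond the scatter, making it the weakest inhibitor of the three in this assay.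

Compound 4 `Cn1c(=O)c(S(=O)(=O)Nc2ccc(F)cc2)cc2cnc(Nc3ccc4[nH]ccc4c3)nc21` has not yet been measured. It differs from compound 1 in a single place: (4-fluorophenyl)amino in place of 2,4-difluorobenzyl on a sulfonyl sulfur. Among the measured compounds shown here, none of the measured pairs makes this particular change, so there is no measured step to lean on; the only guide is that compound 1 and compound 3 carry different groups at the sulfonyl sulfur and still match each other in this assay.

The step from compound 1 to compound 4 is expected to be a 2.0-fold higher number from compound 1 to compound 4 (0.30 log units; within the scatter), a modest move toward a higher number, not far outside the scatter. In this assay compound 4 is therefore estimated at 2000 nM, with a likely range from 500 nM to 10000 nM.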

Compound 4, half-maximal inhibitory concentration: 5000 nM
The estimate for compound 4 lay 2.5-fold (0.40 log units) below the measured number, within the range that was stated.
By their numbers in this assay, from the lowest: compounds 1 and 3 (each within the scatter of the next); then compound 4; then compound 2.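

In this assay, among the compounds shown here, the exchange gives a 5.0-fold higher number from compound 1 to compound 4 (0.70 log units; beyond the scatter) and so provides the first single-place comparison at this sulfonyl sulfur, showing that the group here can change the read-out beyond the scatter, toward weaker inhibition. Both groups carry one six-membered aromatic ring of carbon only, so the step does not come from removing that ring, yet the exchange alters several things at once: the entering (4-fluorophenyl)amino group has a nitrogen and 1 hydrogen-bond donor, and it has 1 fluorine where 2,4-difluorobenzyl has 2. No measurement available here accounts for the step.

This single pair cannot separate the contribution of the nitrogen from that of the fluorine count, and (2,4-difluorophenyl)amino on the same sulfur, with its fluorine pattern matching that of the group it would replace, would help tell them apart. On these data alone, how groups without an aromatic ring, such as dimethylamino or morpholine, would read at this sulfur also remains open.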